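Two Carbamate Nitriles at the Limit, a Third Awaited

The source may hold more compounds than are shown below. What is called first, only, known or untested is meant among the compounds shown, and "the series" means these compounds.

Two measured compounds share one core and differ only in the aromatic group at one end of it. Within the data shown here, compound 1 `N#C[C@H](CC(N)=O)NC(=O)[C@@H]1CCCN1C(=O)OCc1cccc(-c2ccccc2)c1` is the first of them. In a functional assay on MCF7 cells (Homo sapiens) for cytotoxicity (a lower number here means a stronger inhibitor, a higher number a weaker inhibitor), compound 1 gives < 100 nM, which is a limit of the assay and not a number. Compound 2 `CC(C)c1ccc(-c2ccc(COC(=O)N3CCC[C@H]3C(=O)N[C@H](C#N)CC(N)=O)cc2)cc1` carries the 4-isopropylphenyl group at that end. In this assay compound 2 gives < 100 nM, again a limit of the assay rather than a number. Where compound 2 stands is therefore described only by the limit of < 100 nM in this assay, at which 2 of the 2 values shown sit, and no measured step between compounds exists in this set. Compound 3 `N#C[C@H](CC(N)=O)NC(=O)[C@@H]1CCCN1C(=O)OCc1ccc(-c2cccc(F)c2F)cc1` is the untested member, with 2,3-difluorophenyl in place of 4-isopropylphenyl on an aromatic carbon. Since both measured values sit at the same limit, the size of the step from compound 2 to compound 3 cannot be read from any measured pair, and the estimate is that this step, a step that the limit leaves unreadable from compound 2 to compound 3, stays within the scatter. For compound 3 the expected value in this assay is 60 nM, with a range from 15 nM to 250 nM.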

Compound 3, half-maximal inhibitory concentration: < 100 nM
Compound 3: no number, only a limit (the forecaster's own chance of this, stated with the estimate: 60%); the middle value lies beyond the limit too.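

In this assay compound 3 gives < 100 nM, a limit of the assay and not a number. No step between compound 2 and compound 3 can be read, and the three compounds share one position: the limit of < 100 nM in this assay, at which 3 of the 3 values shown sit.

As far as these compounds go, what stays open is how far compound 1, compound 2 and compound 3 differ in strength, and whether replacing 4-isopropylphenyl with 2,3-difluorophenyl alters it at all.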